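A few compounds are considered here, and "the series" means these few. Any claim that something is new, unique, unknown or untested is made for them only; others in the source may bear on it.

Series so far, read in a functional assay on KB cells (Homo sapiens) for inhibition, read by sulforhodamine B assay, with a stated time of 72 h; a higher number here means a weaker inhibitor of growth, a lower number a stronger inhibitor of growth:
- compound 1 `CCOC(=O)/C=C/c1ccncc1-c1ccc2[nH]ccc2c1`: > 10000 nM, a limit
- compound 2 `Cn1ccc2cc(-c3cnccc3/C=C/C(=O)O)ccc21`: > 10000 nM, a limit
- compound 3 `CNC(=O)/C=C/c1ccncc1-c1ccc2[nH]ccc2c1`: > 10000 nM, a limit
- compound 4 `O=C(O)/C=C/c1ccncc1-c1ccc2[nH]ccc2c1`: not yet measured

Compound 3 gives > 10000 nM, which is a limit and not a number. The other two measured compounds are limits of the same kind, so compound 3 cannot be ranked against them. The whole set reads as one result: the limit of > 10000 nM in this assay, at which 3 of the 3 values shown sit.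

The next step puts hydroxy in place of methylamino on a carbonyl carbon, turning methylcarbamoyl into carboxy: hydroxy in place of methylamino on a carbonyl carbon.

Within the data shown here, only one measured step bears on this change, and it acts on the same carbonyl carbon: a step that the two limits leave unreadable from compound 1 to compound 3. Its size cannot be read, so it offers no direction for this assay. Compound 2 also carries a carboxy group on the chain and gives > 10000 nM, a limit. On this basis, no gain in growth inhibition is foreseen, and compound 4 is expected to stay at the limit of the assay.

The expected change is a number no higher from compound 3 to compound 4 (the limit leaves the size open), with no size beyond the scatter foreseen. Compound 4 is estimated at 10000 nM, with an expected range from 4000 nM to 30000 nM.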

Compound 4, concentration for 50% growth inhibition: > 10000 nM
Compound 4 ended at the assay's limit (the forecaster's own chance of this, stated with the estimate: 90%); the middle value sits exactly at the limit.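

No step from compound 1, compound 2 or compound 3 to compound 4 can be read, and the series stays at a single result: the limit of > 10000 nM in this assay, at which 4 of the 4 values shown sit.

The compounds shown leave open how far each lies from that limit, and whether any change on the carbonyl carbon or the aromatic nitrogen affects growth inhibition.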